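From (4-fluorobenzyl)amino to (3,4-dichlorophenyl)sulfanyl

The compounds below may be only part of what the source reports. "The series", "measured", "known", "first", "only" and "open" are said of these compounds alone.

Compound 1 `Nc1cc(N)c2nc(-c3ccccc3)c(NCc3ccc(F)cc3)nc2c1`: < 100000 nM
Compound 2 `COc1ccc(CNc2nc3cc(N)cc(N)c3nc2-c2ccccc2)cc1`: 52500 nM

In a functional assay on HCT-116 cells (Homo sapiens) for inhibition, read by sulforhodamine B assay, with a stated time of 48 h (a higher number here means that more compound is tolerated, a lower number that less compound is tolerated), compound 1 gives < 100000 nM, which is a limit of the assay rather than a number (the limit of < 100000 nM in this assay, at which 1 of the 2 values shown sits). Compound 2 gives 52500 nM in this assay. The step that the limit leaves unreadable from compound 1 to compound 2 cannot be sized, so compound 1 is placed only by its limit.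

Compound 3 `Nc1cc(N)c2nc(-c3ccccc3)c(Sc3ccc(Cl)c(Cl)c3)nc2c1` differs from compound 1 by (3,4-dichlorophenyl)sulfanyl in place of (4-fluorobenzyl)amino on an aromatic carbon. Going by the values given here, no measured step touches this change, and the one measured step, a step that the limit leaves unreadable from compound 1 to compound 2, concerns a different substituent and is itself unreadable. Compound 1 is therefore the only anchor, and compound 3 is expected to stay in the same weakly active region, with an expected step that the limit leaves unreadable from compound 1 to compound 3 not clearly beyond the scatter. Compound 3 is estimated at 60000 nM in this assay, within 15000 nM to 100000 nM.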

Compound 3, concentration lethal to 50% of the cells: < 100000 nM
Compound 3: no number, only a limit; the forecaster's own chance of this, stated with the estimate: 40%; the middle value does not contradict the limit.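

In this assay compound 3 gives < 100000 nM as a limit of the assay, not a number. Compound 1 also stands only at a limit, and no step can be read between compound 1 and compound 3: the limit of < 100000 nM in this assay, at which 2 of the 3 values shown sit. The compounds shown leave open whether (3,4-dichlorophenyl)sulfanyl in place of (4-fluorobenzyl)amino changes the value in this assay at all.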